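The source may report more compounds than this note shows. Statements on the series, on what has been measured and on what is new or still open speak of the compounds shown alone.

Measured compounds: compound 1 `COC(=O)/C=C/c1cccc(N(Cc2ccc(-c3cccc(OC)c3)cc2)C(=O)NC(C)C)c1`, 1370 nM; compound 2 `COC(=O)/C=C/c1cccc(N(Cc2ccc(/C=C/C(=O)OCc3ccccc3)cc2)C(=O)C2CCCCC2)c1`, > 1000 nM; compound 3 `COC(=O)/C=C/c1cccc(N(Cc2ccc(-c3cccc(OC)c3)cc2)C(=O)C(C)C)c1`, 72 nM.

In an assay on isolated protein with Bile acid receptor (Homo sapiens) as the target (on this read-out lower numbers stand for an effect already at smaller amounts and higher numbers for an effect only at larger amounts of compound), compound 1 gives 1370 nM, the highest of the two plain numbers shown. Compound 3 gives 72 nM, and the step of a 19-fold lower number from compound 1 to compound 3 (1.28 log units; beyond the scatter) comes from putting isopropyl in place of isopropylamino on a carbonyl carbon. For compound 2 the result > 1000 nM is a limit of this assay rather than a number (the limit of > 1000 nM in this assay, at which 1 of the 3 values shown sits). Compound 4 `COC(=O)/C=C/c1cccc(N(Cc2ccc(-c3c(OC)cccc3OC)cc2)C(=O)NC(C)C)c1` differs from compound 1 at another part of the molecule: 2,6-dimethoxyphenyl in place of 3-methoxyphenyl on an aromatic carbon. Among the measured compounds shown here, none of the measured steps touches this part, so no measured step bears on the change. The expectation for compound 4 is therefore a step within the usual scatter, a 1.1-fold higher number from compound 1 to compound 4 (0.04 log units; within the scatter), with an estimate of 1500 nM, between 400 nM and 6000 nM.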

Compound 4, half-maximal effective concentration: 561 nM
Compound 4: the middle estimate sits 2.7-fold (0.43 log units) above what was measured, within the range that was stated.
By their numbers in this assay, from the lowest: compound 3; then compound 4; then compound 1.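

In this assay, 2,6-dimethoxyphenyl in place of 3-methoxyphenyl gives a 2.4-fold lower number from compound 1 to compound 4 (0.39 log units; beyond the scatter). Among the compounds shown here, this shows that the aromatic group at this position, which no earlier step touched, also influences the number, although only modestly. Nothing in the data shown explains the step.

On these data alone, it remains open whether 2,6-dimethoxyphenyl would also lower the number when paired with the isopropyl on the carbonyl carbon of compound 3. As far as these compounds go, it is also open how a ring carrying a hydroxyl or an amine in place of methoxy would behave.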